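Dimethylamino for Phenoxy in a Cytotoxicity Series

The compounds below may be only part of what the source reports. "The series", "measured", "known", "first", "only" and "open" are said of these compounds alone.

Measured so far:
compound 1, `COc1cc(C)cc(-c2nn(CC#N)cc2-c2ccc(-c3cccc(C(C)=O)c3)nc2)c1`, 68%;
compound 2, `Cc1cc(O)cc(-c2nn(CC#N)cc2-c2ccnc(-c3ccc(Oc4ccccc4)cc3)c2)c1`, 72%.

In a functional assay on OVCAR-5 cells (Homo sapiens) for cytotoxicity, read by sulforhodamine B assay, with a stated time of 48 h, tested at 0.01 uM (a higher number here means a weaker effect of the compound at the concentration tested, a lower number a stronger effect), compound 2 gives the higher of the two numbers, though compound 1 sits only a few points lower, a gap within the scatter. Compound 3, `Cc1cc(O)cc(-c2nn(CC#N)cc2-c2ccnc(-c3ccc(N(C)C)cc3)c2)c1`, differs from compound 2 in one place: dimethylamino in place of phenoxy on an aromatic carbon. Going by the values given here, no measured pair shows what this exchange does, so only a small step, none beyond the scatter, is expected, a number 2 percentage points lower from compound 2 to compound 3 (within the scatter). Compound 3 is therefore estimated at 70%, within 50% to 90%.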

Compound 3, a percentage reported as activity, at one concentration (the size of the read-out at that concentration, not a potency): 91%
Compound 3: middle estimate off by 21 percentage points, on the low side; the measured number lies above the stated range.
By their numbers in this assay, from the lowest: compounds 1 and 2 (each within the scatter of the next); then compound 3.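

In this assay, dimethylamino in place of phenoxy gives a number 19 percentage points higher from compound 2 to compound 3 (beyond the scatter), so at the concentration tested the effect weakens and this aromatic carbon, para to a large group, is shown not to be indifferent to the change. The exchange removes a six-membered aromatic ring of carbon only, while the hydrogen-bond donors and acceptors counted for the two groups stay the same. Nothing available explains the weaker effect. From the compounds shown here alone, whether the loss follows from losing that ring or from dimethylamino itself remains open. A methoxy group or a morpholine on this carbon would help separate the two.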